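The source may report more compounds than this note shows. Statements on the series, on what has been measured and on what is new or still open speak of the compounds shown alone.

For the measured compounds named here, compound 1 `CCc1nncn1-c1ccc(OCc2cccc(F)c2)cc1` gives 22.8 mg/kg in a functional assay on the whole organism (strain C57B/6) with Mus musculus as the target, in the maximal electroshock model (on this read-out lower numbers stand for an effect already at smaller amounts and higher numbers for an effect only at larger amounts of compound), the lowest of the two numbers so far; compound 2 `CCc1nncn1-c1ccc(OCc2cccc(Cl)c2)cc1` gives 27.4 mg/kg in this assay, and the step of a 1.2-fold higher number from compound 1 to compound 2 (0.08 log units; within the scatter) is the only measured one. Compound 3 `CCCCCCCCOc1ccc(-n2cnnc2CC)cc1` differs from compound 1 by heptyl in place of 3-fluorophenyl on a saturated chain carbon bound to an oxygen on an aromatic ring. Going by the values given here, the one measured step, a swap of one halogen for another, says nothing about exchanging a 3-fluorophenyl for a heptyl, so no measured step bears on this change. Without guidance, only a small shift is expected, and compound 3 is estimated at 35 mg/kg (range 15 mg/kg to 85 mg/kg), a step of a 1.5-fold higher number from compound 1 to compound 3 (0.19 log units; within the scatter).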

Compound 3, dose for half-maximal effect: 8.8 mg/kg
The estimate for compound 3 lay 4.0-fold (0.60 log units) above the measured number; measured number outside the range, below it.
By their numbers in this assay, from the lowest: compound 3; then compounds 1 and 2 (each within the scatter of the next).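

In this assay, an aromatic ring on this saturated chain carbon is not required for the effect: heptyl, which has no ring, gives a 2.6-fold lower number from compound 1 to compound 3 (0.41 log units; beyond the scatter) and a 3.1-fold lower number from compound 2 to compound 3 (0.49 log units; beyond the scatter). Both steps are modest but beyond the scatter, whereas swapping one halogen for the other stayed within it. Nothing measured here explains why the open chain gives the lower number. Going by these compounds, whether a shorter chain such as butyl or a longer one such as decyl would lower the number further remains open. So does the outcome with an amine in place of heptyl.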